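Replacing 2,4-dichlorophenyl with 3,4-dihydroxyphenyl in a cytotoxicity series

A few compounds are considered here, and "the series" means these few. Any claim that something is new, unique, unknown or untested is made for them only; others in the source may bear on it.

Two compounds have been measured in a functional assay on HT-1080 cells (Homo sapiens) for cytotoxicity, read by MTT assay, with a stated time of 72 h (a higher number here means a weaker inhibitor, a lower number a stronger inhibitor), so far:
Compound 1 `COc1cccc(/C=C2\CCC/C(=C\c3cccc(O)c3)C2=O)c1OC` gives 8500 nM
Compound 2 `COc1cccc(/C=C2\CCC/C(=C\c3ccc(Cl)cc3Cl)C2=O)c1OC` gives > 20000 nM

For compound 2 the reading of > 20000 nM is only a limit of this assay and provides no number to start from.

The next compound, compound 3 `COc1cccc(/C=C2\CCC/C(=C\c3ccc(O)c(O)c3)C2=O)c1OC`, keeps the shared core and changes one group, on a double-bonded chain carbon bound to a double-bonded ring carbon. It carries 3,4-dihydroxyphenyl in place of 2,4-dichlorophenyl on a double-bonded chain carbon bound to a double-bonded ring carbon.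

Within the data shown here, one measured step bears on this change. Among the measured compounds shown here, with 2,4-dichlorophenyl in place of 3-hydroxyphenyl at the same place, the data show an at least 2.3-fold higher number from compound 1 to compound 2 (0.37 log units; beyond the scatter) as the only comparison. Compound 3 goes the opposite way, back from the dichlorophenyl group to a hydroxyphenyl group, so a move toward a lower number is expected in this assay, likely of at least similar size.

The expected step is estimated as an at least 3.3-fold lower number from compound 2 to compound 3 (0.52 log units; beyond the scatter) in that direction.

For compound 3 the estimated value is 6000 nM, with an expected range from 2000 nM to 18000 nM.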

Compound 3, half-maximal inhibitory concentration: 4700 nM
The estimate for compound 3 lay 1.3-fold (0.11 log units) above the measured number, and the stated range covers the measured number.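

Placing 3,4-dihydroxyphenyl on a double-bonded chain carbon bound to a double-bonded ring carbon, in place of 2,4-dichlorophenyl, gives an at least 4.2-fold lower number from compound 2 to compound 3 (0.62 log units; beyond the scatter) in this assay, so compound 1 and compound 3, each with a hydroxy-bearing phenyl group, now both stand apart from compound 2. The reading for compound 2 is a limit and not a number, which leaves the full size of this step unknown: the limit of > 20000 nM in this assay, at which 1 of the 3 values shown sits. The second hydroxy group does not separate the two hydroxylated compounds, as hydroxy in place of hydrogen on an aromatic carbon gives a 1.8-fold lower number from compound 1 to compound 3 (0.26 log units; within the scatter).

The compounds shown leave open whether the gap to compound 2 goes with the hydroxy groups entering or with the chlorine atoms leaving, as a single change replaces both. From the compounds shown here alone, it also remains open how a methoxy group, an amine or a carboxylic acid on this aromatic ring would read in this assay.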